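The source may report more compounds than this note shows. Statements on the series, on what has been measured and on what is new or still open speak of the compounds shown alone.

Measured so far:
compound 1, `O=C1NCCN1c1ccc(S(=O)(=O)Nc2ccc(OC(F)F)cc2)cc1`: 410 nM
compound 2, `Cc1cccc(NS(=O)(=O)c2ccc(N3CCNC3=O)cc2)c1C`: 110 nM
compound 3, `Cc1cccc(NS(=O)(=O)c2ccc(N3CCNC3=O)cc2)c1`: 69 nM

Of the compounds shown here, three sharing one core have been tested in a functional assay on M21 cells (Homo sapiens) for antiproliferative activity, read by sulforhodamine B assay, with a stated time of 48 h; on this read-out lower numbers stand for stronger inhibition and higher numbers for weaker inhibition. Compound 1 gives 410 nM, compound 2 gives 110 nM and compound 3 gives 69 nM. Among the compounds with values here, compound 3 has the lowest of the three numbers; its nearest neighbour is compound 2, and the only step that changes one place, a 1.6-fold lower number from compound 2 to compound 3 (0.20 log units; within the scatter), stays within the scatter. The gap to compound 1 is wider and lies beyond the scatter, but compound 1 differs in more than one place, so only its value can be compared.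

Compound 4, `Cc1ccc(NS(=O)(=O)c2ccc(N3CCNC3=O)cc2)cc1`, has not yet been measured. It differs from compound 3 in this way: 4-methylphenyl in place of 3-methylphenyl on a sulfonamide nitrogen. Within the data shown here, the only measured step that touches the methyl pattern on the same ring is the one from compound 2 to compound 3, and that step was small. The shift of one methyl from one position to another is therefore expected to move this assay by no more than the scatter, in no certain direction, so the estimate for compound 4 is 90 nM with a range from 40 nM to 250 nM, which means an expected step of a 1.3-fold higher number from compound 3 to compound 4 (0.12 log units; within the scatter).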

Compound 4, half-maximal inhibitory concentration: 260 nM
Compound 4: middle estimate off by 2.9-fold (0.46 log units), on the low side; the whole stated range lies below it.
By their numbers in this assay, from the lowest: compounds 3 and 2 (each within the scatter of the next); then compounds 4 and 1 (each within the scatter of the next).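

In this assay, moving a single methyl with no atom gained or lost gives a 3.8-fold higher number from compound 3 to compound 4 (0.58 log units; beyond the scatter), beyond the scatter, whereas the earlier step on this ring, the loss of a methyl from compound 2, stayed within it; the group on the sulfonamide nitrogen therefore matters here through where its methyl stands, and not only through which atoms it carries. The comparison with 2,3-dimethylphenyl points the same way, with a 2.4-fold higher number from compound 2 to compound 4 (0.37 log units; beyond the scatter) also beyond the scatter, while a 1.6-fold lower number from compound 1 to compound 4 (0.20 log units; within the scatter) stays within the scatter, so methyl and difluoromethoxy on that aromatic carbon cannot be told apart in this read-out. Nothing available explains why the 4-methylphenyl group differs from the 3-methylphenyl group.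

The compounds shown leave open whether this dependence on position belongs to methyl alone or would also appear with a chlorine or a methoxy group on the same ring. They also leave open how a plain phenyl group on the sulfonamide nitrogen would compare with the methylated rings in this assay.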